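Replacing an alpha-fluoro acid with a dimethyl-branched acid

The compounds below may be only part of what the source reports. "The series", "measured", "known", "first", "only" and "open" are said of these compounds alone.

Among the measured compounds shown here, compound 2 `COc1ccc(F)c([C@H]2CC[C@H](COc3cccc([C@H](C4CC4)[C@@H](F)C(=O)O)c3)CC2)c1` is one of two compounds measured in a functional assay on cells for agonist activity at Free fatty acid receptor 1 (Homo sapiens), read by HTRF and inositol phosphate accumulation, with a stated time of 90 min; on this read-out lower numbers stand for an effect already at smaller amounts and higher numbers for an effect only at larger amounts of compound. In this assay compound 2 gives 20 nM. Its only comparator, compound 1 `COc1ccc(F)c([C@H]2CC[C@H](COc3cccc([C@H](C4CC4)[C@@H](C)C(=O)O)c3)CC2)c1`, gives 22 nM in this assay, and the step of a 1.1-fold lower number from compound 1 to compound 2 (0.04 log units; within the scatter) lies within the scatter, so the two values cannot be told apart.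

Compound 3 `COc1ccc(F)c([C@H]2CC[C@H](COc3cccc([C@H](C4CC4)C(C)(C)C(=O)O)c3)CC2)c1` has not yet been measured. It differs from compound 2 in this way: 1-carboxy-1-methylethyl in place of carboxy(fluoro)methyl on a saturated chain carbon bound to an aromatic carbon and a saturated ring carbon. The leaving group carries a fluorine and a defined stereocentre; the entering group carries two carbons in their place and no stereocentre.

For the measured compounds named here, only one measured step bears on this change. The step of a 1.1-fold lower number from compound 1 to compound 2 (0.04 log units; within the scatter) showed that swapping methyl for fluoro at the carbon bound to the carbonyl carbon left the number unchanged within scatter. Going by the values given here, no measured step shows what adding a second group at that carbon does, so the expectation rests on a single neighbouring observation.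

Compound 3 is therefore expected to give 40 nM in this assay, within a range of 12 nM to 130 nM, an expected step of a 2.0-fold higher number from compound 2 to compound 3 (0.30 log units; within the scatter) that may not exceed the scatter.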

Compound 3, half-maximal effective concentration: 220 nM
For compound 3 the middle estimate is 5.5-fold (0.74 log units) below the measured one, and the stated range ends below it.
By their numbers in this assay, from the lowest: compounds 2 and 1 (each within the scatter of the next); then compound 3.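

Until now, the group at this place had been varied only between carboxy(fluoro)methyl and 1-carboxyethyl, with no visible effect on the number in this assay, and 1-carboxy-1-methylethyl ends that flat picture, with an 11-fold higher number from compound 2 to compound 3 (1.04 log units; beyond the scatter) and a 10-fold higher number from compound 1 to compound 3 (1.00 log units; beyond the scatter). Among these three compounds, exchanging methyl for fluoro changes little, whereas the group that carries two methyl groups gives a step well beyond the scatter from either neighbour, so this place is clearly not indifferent to what it carries. Going to compound 3 also removes the defined stereocentre, so the added methyl and the lost stereocentre cannot be separated, and no measurement shown here explains the rise.

The compounds shown leave open whether the loss comes from having two groups on that carbon at all, which carboxydifluoromethyl, with two fluorine atoms in place of the two methyl groups, would help to test. They also leave open how the plain carboxymethyl group, or 1-carboxycyclopropyl with the two methyl carbons tied into a ring, would compare with the three groups seen so far.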